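The source may hold more compounds than are shown below. What is called first, only, known or untested is meant among the compounds shown, and "the series" means these compounds.

Measured in a functional assay on HT-29 cells (Homo sapiens) for antiproliferative activity, read by sulforhodamine B assay, with a stated time of 48 h; a lower number here means a stronger inhibitor, a higher number a weaker inhibitor:
- Compound 1 `CCCCN1CCN(c2ccc(S(=O)(=O)Oc3ccccc3)cc2)C1=O`: > 100000 nM, a limit
- Compound 2 `CCCCN1CCN(c2ccc(S(=O)(=O)Oc3ccccc3OC)cc2)C1=O`: > 100000 nM, a limit
- Compound 3 `CCCCN1CCN(c2ccc(S(=O)(=O)Oc3ccc(F)c(F)c3)cc2)C1=O`: > 100000 nM, a limit

In this assay compound 3 gives > 100000 nM, which is a limit and not a number. Among the measured compounds shown here, the series so far shows (the limit of > 100000 nM in this assay, at which 3 of the 3 values shown sit).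

Compound 4 `CCCCN1CCN(c2ccc(S(=O)(=O)Oc3ccc(OC)cc3)cc2)C1=O` carries 4-methoxyphenyl in place of 3,4-difluorophenyl on an oxygen.

The closest measured changes are a step that the two limits leave unreadable from compound 2 to compound 3 and a step that the two limits leave unreadable from compound 1 to compound 3, and a step that the two limits leave unreadable from compound 1 to compound 2 also bears on it. None gives a size to carry over, so no step beyond the scatter is expected in this assay.

The expected step is a number no higher from compound 3 to compound 4 (the limit leaves the size open).

For compound 4 the estimate is 100000 nM, with an expected range from 40000 nM to 200000 nM.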

Compound 4, half-maximal inhibitory concentration: 35000 nM
Compound 4: middle estimate off by 2.9-fold (0.46 log units), on the high side; the measured number lies below the stated range.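

In this assay the group on the oxygen bonded to the sulfonyl sulfur first gives a readable number with 4-methoxyphenyl, which shows an at least 2.8-fold lower number from compound 3 to compound 4 (0.45 log units; beyond the scatter) against 3,4-difluorophenyl. The position of the methoxy group counts, since 4-methoxyphenyl in place of 2-methoxyphenyl gives an at least 2.8-fold lower number from compound 2 to compound 4 (0.45 log units; beyond the scatter) in this series. Against plain phenyl the result is an at least 2.8-fold lower number from compound 1 to compound 4 (0.45 log units; beyond the scatter) for the same 4-methoxyphenyl group.

Open, on these data alone, is whether an amine or a carboxylic acid on this phenyl ring would lower the number further. The steps among compound 1, compound 2 and compound 3 cannot be read: the limit of > 100000 nM in this assay, at which 3 of the 4 values shown sit.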